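The source may report more compounds than this note shows. Statements on the series, on what has been measured and on what is new or still open speak of the compounds shown alone.

Measured in a functional assay on HL-60 cells (Homo sapiens) for inhibition, read by MTT assay, with a stated time of 72 h, tested at 30 uM; a lower number here means less inhibition of growth, a higher number more inhibition of growth at the concentration tested
Compound 1 (`C=CCc1ccc(OCc2cn(-c3cc(OC)c(OC)c(OC)c3)nn2)c(O)c1`) gives 32.8%
Compound 2 (`C=CCc1ccc(OCc2cn(-c3ccccc3Cl)nn2)c(O)c1`) gives 38.7%
Compound 3 (`C#CCOc1ccc(CC=C)cc1O`) gives 30.7%

On these numbers, compound 2 lies within the scatter of both compound 1 and compound 3, so the three are not separated from one another. Compound 4 (`C=CCc1ccc(OCc2cn(-c3ccccc3CO)nn2)c(O)c1`) is still unmeasured. It carries hydroxymethyl in place of chloro on an aromatic carbon, ortho to a large group (hydroxymethyl in place of chloro on an aromatic carbon), so that 2-chlorophenyl becomes 2-(hydroxymethyl)phenyl. For the measured compounds named here, no pair of measured compounds differs in one place, so the data offer no direct precedent for this change. In this assay no step beyond the scatter is expected, and no firm direction can be given: compound 1 at 32.8% and compound 3 at 30.7% differ from compound 2 in much more of their structure, yet remain within its scatter. The estimate therefore means a number 5.7 percentage points lower from compound 2 to compound 4 (within the scatter) and nothing larger. For compound 4 the expected value is 33% within an estimated range (20% to 46%).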

Compound 4, percent growth inhibition at one concentration: 31.7%
Beside the measured number, compound 4's estimate is 1.3 percentage points above it, within the range that was stated.
By their numbers in this assay, from the lowest: compounds 3, 4, 1 and 2 (each within the scatter of the next).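

In this assay, the exchange of chloro for hydroxymethyl on an aromatic carbon, ortho to a large group, provides the only one-place comparison among these compounds, with a number 7 percentage points lower from compound 2 to compound 4 (within the scatter) as its step. At this position, therefore, 2-chlorophenyl and 2-(hydroxymethyl)phenyl are not separated, even though the entering group carries one hydrogen-bond donor and one hydrogen-bond acceptor and the leaving chloro carries neither. No available measurement bears on this result. On these data alone, what an amine, a carboxylic acid or a longer chain at this position would give in this assay remains open, as does whether any group there can produce a step beyond the scatter. Also open, as far as these compounds go, is how this exchange would read across a range of concentrations rather than at a single one.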